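The compounds below may be only part of what the source reports. "The series", "measured", "known", "first", "only" and "open" are said of these compounds alone.

Compound 1 `O=c1cc(/C=N\Nc2ccc([N+](=O)[O-])cc2)c2ccc(OCc3ccccc3)cc2o1`: > 2000000 nM, a limit
Compound 2 `O=c1cc(/C=N\O)c2ccc(OCc3ccccc3)cc2o1`: > 2000000 nM, a limit
Compound 3 `N/N=C\c1cc(=O)oc2cc(OCc3ccccc3)ccc12`: 131000 nM

Among the compounds with values here, in a functional assay, read by spectrophotometry, with a stated time of 5 min (a higher number here means a weaker inhibitor, a lower number a stronger inhibitor), compound 3 holds the only true number, as the other two values are limits. Compound 4 `O=c1cc(/C=N\c2ccccc2O)c2ccc(OCc3ccccc3)cc2o1` differs from compound 3 by 2-hydroxyphenyl in place of amino on a double-bonded nitrogen, with 2-hydroxyphenyl in place of amino on a double-bonded nitrogen. Within the data shown here, two measured steps bear on this change: an at least 15-fold lower number from compound 1 to compound 3 (1.18 log units; beyond the scatter) and an at least 15-fold lower number from compound 2 to compound 3 (1.18 log units; beyond the scatter). Both are large and beyond the scatter. Compound 1 also carries a substituted phenyl group on this side of the shared core, so a large move to a higher number is expected in this assay, perhaps as far as the limit. The expected step is a 3.8-fold higher number from compound 3 to compound 4 (0.58 log units; beyond the scatter). For compound 4 the estimate is 500000 nM, expected to lie between 100000 nM and 2000000 nM.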

Compound 4, half-maximal inhibitory concentration: 469000 nM
The estimate for compound 4 lay 1.1-fold (0.03 log units) above the measured number; measured number inside the range.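

In this assay, within the data shown here, amino is not the only group on the double-bonded nitrogen that gives a true number: 2-hydroxyphenyl in its place gives a 3.6-fold higher number from compound 3 to compound 4 (0.55 log units; beyond the scatter). The same group also separates from hydroxy and from (4-nitrophenyl)amino, with an at least 4.2-fold lower number from compound 2 to compound 4 (0.62 log units; beyond the scatter) and an at least 4.2-fold lower number from compound 1 to compound 4 (0.62 log units; beyond the scatter). These last two steps start from limits, so they give bounds and not sizes: the limit of > 2000000 nM in this assay, at which 2 of the 4 values shown sit.

Going by these compounds, it remains open whether the hydroxy on the 2-hydroxyphenyl group matters for this step, as an unsubstituted phenyl would show. A methylamino group would show whether a small amine on this nitrogen holds the number near that of compound 3.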